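Swapping the Chain Amine in a Cytotoxic Series

The compounds below may be only part of what the source reports. "The series", "measured", "known", "first", "only" and "open" are said of these compounds alone.

Three compounds have been measured in a functional assay on MDA-MB-231 cells (Homo sapiens) for cytotoxicity, read by MTT assay, with a stated time of 72 h; on this read-out lower numbers stand for stronger inhibition and higher numbers for weaker inhibition:

compound 1 `COc1cc2c(Oc3ccc(NC(=O)c4nn(-c5ccccc5)c(=O)c5ccccc45)cc3F)ccnc2cc1OCCCN1CCCC1` gives 1130 nM
compound 2 `COc1cc2c(Oc3ccc(NC(=O)c4nn(-c5ccccc5F)c(=O)c5ccccc45)cc3F)ccnc2cc1OCCCN1CCCC1` gives 950 nM
compound 3 `COc1cc2c(Oc3ccc(NC(=O)c4nn(-c5ccc(Br)cc5)c(=O)c5ccccc45)cc3F)ccnc2cc1OCCCN1CCCC1` gives 1160 nM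

Compound 1 stands second highest of these three numbers. Its nearest neighbour is compound 3, with a 1.0-fold higher number from compound 1 to compound 3 (0.01 log units; within the scatter), and its furthest is compound 2, with a 1.2-fold lower number from compound 1 to compound 2 (0.08 log units; within the scatter). The remaining step, a 1.2-fold higher number from compound 2 to compound 3 (0.09 log units; within the scatter), is likewise within the scatter, so the three measured compounds cannot be told apart on this read-out.

Compound 4 `COc1cc2c(Oc3ccc(NC(=O)c4nn(-c5ccccc5)c(=O)c5ccccc45)cc3F)ccnc2cc1OCCCN1CCC(C)CC1` differs from compound 1 in the chain amine: 4-methylpiperidin-1-yl in place of pyrrolidin-1-yl on a saturated chain carbon, three bonds along the chain from an oxygen on an aromatic ring.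

Going by the values given here, none of the measured steps touches this part of the molecule; each of them changes only the aryl group on the ring nitrogen, and none moved beyond the scatter. Among the compounds with values here, there is therefore no measured step that bears directly on the change to compound 4, and no basis to expect a step in this assay beyond the scatter in either direction. Compound 4 is therefore expected to give 1100 nM, within a range of 450 nM to 2700 nM. This estimate corresponds to an expected step of a 1.0-fold lower number from compound 1 to compound 4 (0.01 log units; within the scatter).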

Compound 4, half-maximal inhibitory concentration: 1480 nM
Estimate against measurement, compound 4: 1.3-fold (0.13 log units) below, within the range that was stated.
By their numbers in this assay, from the lowest: compounds 2, 1, 3 and 4 (each within the scatter of the next).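

Going by these compounds alone, this is the first compound to alter the chain amine rather than the aryl group on the ring nitrogen, and in this assay the swap gives a 1.3-fold higher number from compound 1 to compound 4 (0.12 log units; within the scatter) and so stays within the scatter. At this position, on a saturated chain carbon three bonds along the chain from an oxygen on an aromatic ring, 4-methylpiperidin-1-yl can therefore stand in place of pyrrolidin-1-yl with no difference that this read-out can separate. Nothing available here links this result to any property of either amine.

Still open, as far as these compounds go, is whether morpholin-4-yl or an open-chain dimethylamino group at the same place would also leave the number within the scatter. The compounds shown also leave open what a shorter chain between the oxygen and the amine would do.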